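Fluoro for methyl on the distal aryl ring

The compounds below may be only part of what the source reports. "The series", "measured", "known", "first", "only" and "open" are said of these compounds alone.

Compound 1 `COc1cc(-c2ccc(C)n2-c2ccc(-c3nc4ccccc4s3)cc2)cc(OC)c1OC` gives 3450 nM in a functional assay on MDA-MB-231 cells (Homo sapiens) for cytotoxicity, read by sulforhodamine B assay, with a stated time of 48 h; on this read-out lower numbers stand for stronger inhibition of growth and higher numbers for weaker inhibition of growth.
Compound 2 `COc1ccc2nc(-c3ccc(-n4c(C)ccc4-c4ccc(C)cc4)cc3)sc2c1` gives 4010 nM.
Compound 3 `COc1cc2nc(-c3ccc(-n4c(C)ccc4-c4ccc(C)cc4)cc3)sc2c(OC)c1OC` gives 4140 nM.

The three measured compounds all fall within a narrow band in this assay, and none of the gaps between them is wider than the usual scatter. Compound 3 sits at the upper end of that band, yet its distances to compound 2 and to compound 1 are both within the scatter, so the three numbers cannot be told apart.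

Compound 4 `COc1cc2nc(-c3ccc(-n4c(C)ccc4-c4ccc(F)cc4)cc3)sc2c(OC)c1OC` has not yet been measured. It differs from compound 3 in one place: fluoro in place of methyl on an aromatic carbon. Within the data shown here, no pair among the measured compounds shows the effect of such a single-atom swap on this ring, so there is no measured step to lean on. Given how little the three measured compounds differ from one another, the step from compound 3 to compound 4 is expected to be small, with no direction that rises above the scatter, a 1.0-fold lower number from compound 3 to compound 4 (0.01 log units; within the scatter). Compound 4 is therefore estimated at 4000 nM, in a range from 2000 nM to 8000 nM.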

Compound 4, concentration for 50% growth inhibition: 3940 nM
Beside the measured number, compound 4's estimate is 1.0-fold (0.01 log units) above it, within the range that was stated.
By their numbers in this assay, from the lowest: compounds 1, 4, 2 and 3 (each within the scatter of the next).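

Fluoro in place of methyl, read here as 4-methylphenyl to 4-fluorophenyl, gives the first step in this set between compounds that differ in one place: in this assay there is a 1.1-fold lower number from compound 3 to compound 4 (0.02 log units; within the scatter). The earlier compounds shown here differed in more than one place and so could say nothing about this position taken alone, whereas here the two groups, on a six-membered aromatic ring and para to a large group, give numbers that cannot be told apart. No supporting measurement is available that could account for this result.

On these data alone, whether an amine, a carboxylic acid or a trifluoromethyl group at this position would give a step beyond the scatter remains open. So does whether fluoro in place of methyl would read the same on the core of compound 2.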